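The source may hold more compounds than are shown below. What is called first, only, known or untested is meant among the compounds shown, and "the series" means these compounds.

Of the compounds shown here, three have been tested in a functional assay on MCF7 cells (Homo sapiens) for inhibition, read by fluorescence, with a stated time of 72 h; on this read-out higher numbers stand for weaker inhibition of growth and lower numbers for stronger inhibition of growth. Compound 1 `Cc1nccc2nn(-c3ccccc3)cc12` is the starting point. In this assay compound 1 gives > 100000 nM, which is a limit of the assay rather than a number. Compound 3 `Cn1cc2cnc(-c3ccccc3)cc2n1` sits at the same place: in this assay compound 3 gives > 100000 nM, again a limit. Within the data shown here, compound 2 `CC(C)c1nc(-c2ccccc2)cc2nn(-c3ccccc3)cc12` is the only one with a number: in this assay compound 2 gives 91000 nM. Among the measured compounds shown here, compound 1 therefore stands at the limit of > 100000 nM in this assay, at which 2 of the 3 values shown sit, with no measured number of its own, and there is no pair of measured compounds differing in one place that could guide an expectation.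

Compound 4 `CCCCc1cc2nn(-c3ccccc3)cc2c(C)n1` has not been measured. It differs from compound 1 in one place: butyl in place of hydrogen on an aromatic carbon. With compound 1 at the limit and the other two compounds weak as well, the change is expected to move the result little, if at all, beyond the scatter, an at least 1.1-fold lower number from compound 1 to compound 4 (0.04 log units; that floor lies within the scatter). Compound 4 is estimated at 90000 nM, in a range from 30000 nM to 300000 nM, with a fair chance that only a limit is reported.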

Compound 4, concentration for 50% growth inhibition: 11100 nM
Estimate against measurement, compound 4: 8.1-fold (0.91 log units) above; the whole stated range lies above it.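

Butyl in place of hydrogen on this aromatic carbon, next to the ring nitrogen, gives an at least 9.0-fold lower number from compound 1 to compound 4 (0.95 log units; beyond the scatter) in this assay. This is the first change among the compounds shown that can be read as a step, and it shows that this position on the core of compound 1 is not indifferent to what it carries, even when the new group is a plain chain with no hydrogen-bond donors or acceptors. The step gives only a minimum size, not an exact one, as compound 1 has only a limit as its starting point: the limit of > 100000 nM in this assay, at which 2 of the 4 values shown sit.

Going by these compounds, whether the chain length matters remains open, as a shorter ethyl chain or a longer hexyl chain would be needed to tell. Also open, on these data alone, is whether a group of a different kind at this position, such as an amine or a carboxylic acid, would keep the change.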